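Swapping Iodo for Trifluoromethyl on a Weak Urea

The compounds below may be only part of what the source reports. "The series", "measured", "known", "first", "only" and "open" are said of these compounds alone.

Measured compounds in a functional assay on NCI-H226 cells (Homo sapiens) for antiproliferative activity, read by MTT assay, with a stated time of 48 h; a higher number here means a weaker inhibitor, a lower number a stronger inhibitor:
compound 1, `COc1ccc(OC)c(Nc2cc(NC(=O)Nc3c(Cl)cccc3Cl)ncn2)c1`, 2260 nM
compound 2, `COc1cc(NC(=O)Nc2cc(Nc3cc(I)ccc3OC)ncn2)cc(OC)c1`, 19400 nM

Compound 2 has the higher of the two numbers, so it is the weaker inhibitor of the pair. Compound 3, `COc1cc(NC(=O)Nc2cc(Nc3cc(C(F)(F)F)ccc3OC)ncn2)cc(OC)c1`, has not been measured yet. It differs from compound 2 in one place: trifluoromethyl in place of iodo on an aromatic carbon. Going by the values given here, no step between measured compounds is known here, so there is no guide for how this exchange moves the number. For compound 3 the step of a 1.3-fold lower number from compound 2 to compound 3 (0.11 log units; within the scatter) is expected to be small, not beyond the usual scatter. Compound 3 is estimated at 15000 nM, likely between 5000 nM and 45000 nM.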

Compound 3, half-maximal inhibitory concentration: 14600 nM
Compound 3: middle estimate off by 1.0-fold (0.01 log units), on the high side, and the stated range covers the measured number.
By their numbers in this assay, from the lowest: compound 1; then compounds 3 and 2 (each within the scatter of the next).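

In this assay trifluoromethyl in place of iodo, on the aromatic carbon para to a methoxy group, gives a 1.3-fold lower number from compound 2 to compound 3 (0.12 log units; within the scatter) and so the two compounds cannot be told apart. At this position, a group of 4 heavy atoms and a group of 1 heavy atom read the same. Nothing shown here explains this result. As far as these compounds go, an amine, a carboxylic acid or a longer chain at this position remains open. So does whether this exchange would read the same on a more potent urea.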